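The source may hold more compounds than are shown below. What is called first, only, known or untested is meant among the compounds shown, and "the series" means these compounds.

Compound 1 `Nc1ncc(-c2cncc(NS(=O)(=O)c3ccccc3)c2)cn1` and compound 2 `Cc1ccc(S(=O)(=O)Nc2cncc(-c3cnc(N)nc3)c2)cc1` share one core and differ only at one aromatic carbon, where compound 2 carries a methyl. In an assay on isolated protein for binding affinity to phosphatidylinositol 4,5-bisphosphate 3-kinase catalytic subunit beta isoform (Homo sapiens) (a lower number here means tighter binding, a higher number weaker binding), compound 1 gives 360 nM, and compound 2 gives 100 nM, the lowest of the two numbers measured here. Among the measured compounds shown here, that gap, a 3.6-fold lower number from compound 1 to compound 2 (0.56 log units; beyond the scatter), is the only step measured so far. Compound 3 `Nc1ncc(-c2cncc(NS(=O)(=O)c3ccc([N+](=O)[O-])cc3)c2)cn1` takes the next step: nitro in place of methyl on an aromatic carbon. For the measured compounds named here, no measured step exchanges one group for another at that carbon, so the single step from compound 1 to compound 2 is the only guide, and it shows that a change at this carbon can move the number by a modest amount. The estimate for compound 3 is therefore cautious and carries a wide range, with a 2.0-fold higher number from compound 2 to compound 3 (0.30 log units; within the scatter) expected. Compound 3 is expected to give about 200 nM in this assay, between 60 nM and 700 nM.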

Compound 3, dissociation constant: 550 nM
For compound 3 the middle estimate is 2.8-fold (0.44 log units) below the measured one, within the range that was stated.
By their numbers in this assay, from the lowest: compound 2; then compounds 1 and 3 (each within the scatter of the next).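

Replacing methyl with nitro at this aromatic carbon, para to a large group, gives in this assay a 5.5-fold higher number from compound 2 to compound 3 (0.74 log units; beyond the scatter) and so undoes the advantage that compound 2 holds. Nitro in place of hydrogen gives a 1.5-fold higher number from compound 1 to compound 3 (0.18 log units; within the scatter) and so leaves no difference that can be read, which means this carbon does not respond to every added group as it does to methyl. Nothing available explains why methyl and nitro part ways here.

With only hydrogen, methyl and nitro shown at this carbon, it remains open whether an ethyl group, a chlorine atom or an amine would track methyl, track nitro or do something else. As far as these compounds go, it also remains open whether any of these groups would give the same result elsewhere on the same ring.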